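This account rests on a few compounds, and the source may have more. Where it says the series, first, only, none or still open, it means among the compounds named here.

Measured in an ADME assay on CCRF-HSB-2 cells (Homo sapiens) for cytotoxicity, with a stated time of 7 days; a higher number here means that more compound is tolerated, a lower number that less compound is tolerated:
compound 1 `CNc1nc(N)nc2c1ncn2/C=C1/CC1(CO)CO`: > 20000 nM (a limit)
compound 2 `CCCCCCCCOc1nc(N)nc2c1ncn2/C=C1/CC1(CO)CO`: > 20000 nM (a limit)
compound 3 `CC(C)Nc1nc(N)nc2c1ncn2/C=C1/CC1(CO)CO`: > 20000 nM (a limit)

Compound 3 has no exact number in this assay: compound 3 gives > 20000 nM, which is a limit. It shares that position with the other two measured compounds, as the record shows: the limit of > 20000 nM in this assay, at which 3 of the 3 values shown sit.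

Compound 4 `CSc1nc(N)nc2c1ncn2/C=C1/CC1(CO)CO` has methylsulfanyl in place of isopropylamino on an aromatic carbon, next to the ring nitrogen (methylsulfanyl in place of isopropylamino on an aromatic carbon). The measured steps that bear on this change are a step that the two limits leave unreadable from compound 1 to compound 2, a step that the two limits leave unreadable from compound 1 to compound 3 and a step that the two limits leave unreadable from compound 2 to compound 3. None of them has a readable size, but methylamino, octyloxy and isopropylamino all end at the same limit. No step beyond the scatter is therefore expected in this assay, and no direction can be favoured. The expected change is a number no higher from compound 3 to compound 4 (the limit leaves the size open). The estimated value for compound 4 is 20000 nM. The expected range for compound 4 runs from 9000 nM to 40000 nM.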

Compound 4, half-maximal cytotoxic concentration: > 100000 nM
Compound 4 ended at the assay's limit; the forecaster's own chance of this, stated with the estimate: 80%; middle value at least 5.0-fold (0.69 log units) from the limit.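

Among the compounds shown here, compound 4 ends at a limit, as do compound 1, compound 2 and compound 3, and no step from any of these three to compound 4 can be read. The compounds shown leave open whether methylamino, octyloxy, isopropylamino and methylsulfanyl differ at all in this assay.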